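A Methyl Added to Compound 3

The source may report more compounds than this note shows. Statements on the series, on what has been measured and on what is new or still open speak of the compounds shown alone.

Compound 3 `N/C(=N\NC(=S)N1CCCC1)c1ccccn1` gives 3600 nM in a functional assay on MCF7 cells (Homo sapiens) for cytotoxicity, read by MTT assay, with a stated time of 72 h (a lower number here means a stronger inhibitor, a higher number a weaker inhibitor), the lowest of the three numbers measured. Compound 1 `Cc1ccnc(/C(N)=N/NC(=S)N2CCSCC2)c1` gives 6900 nM in this assay, a gap from compound 3 that lies within the scatter, while compound 2 `N/C(=N\NC(=S)N1CCSCC1)c1ccccn1` gives 8800 nM in this assay, the step being a 2.4-fold lower number from compound 2 to compound 3 (0.39 log units; beyond the scatter). Compound 4 `Cc1ccnc(/C(N)=N/NC(=S)N2CCCC2)c1` differs from compound 3 by methyl in place of hydrogen on an aromatic carbon. Going by the values given here, the only measured step bearing on this change is its reverse, a 1.3-fold higher number from compound 1 to compound 2 (0.11 log units; within the scatter), so no step beyond the scatter is expected in this assay. Compound 4 is therefore expected to give about 3000 nM, between 1500 nM and 6000 nM, which would mean a step of a 1.2-fold lower number from compound 3 to compound 4 (0.08 log units; within the scatter) that is expected to stay within the scatter.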

Compound 4, half-maximal inhibitory concentration: 1200 nM
Beside the measured number, compound 4's estimate is 2.5-fold (0.40 log units) above it; measured number below the stated range.
By their numbers in this assay, from the lowest: compound 4; then compounds 3, 1 and 2 (each within the scatter of the next, the first and the last beyond it).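

In this assay, methyl on the aromatic carbon opposite the ring nitrogen now gives a step beyond the scatter, a 3.0-fold lower number from compound 3 to compound 4 (0.48 log units; beyond the scatter), yet this step cannot be told apart from the earlier one on the other core: the same change on two cores in this assay, a 1.3-fold higher number (0.11 log units; within the scatter) from compound 1 to compound 2 and a 3.0-fold higher number (0.48 log units; beyond the scatter) from compound 4 to compound 3, 2.4-fold (0.37 log units) apart, within the scatter of two such steps. Pyrrolidin-1-yl in place of thiomorpholin-4-yl also lowers the number on the core carrying methyl, a 5.8-fold lower number from compound 1 to compound 4 (0.76 log units; beyond the scatter), in agreement with the same change on the core without it: the same change on two cores in this assay, a 2.4-fold lower number (0.39 log units; beyond the scatter) from compound 2 to compound 3 and a 5.8-fold lower number (0.76 log units; beyond the scatter) from compound 1 to compound 4, 2.4-fold (0.37 log units) apart, within the scatter of two such steps.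

The compounds shown leave open whether ethyl, methoxy or an amine on this carbon would carry the number lower still. They also leave open whether a piperidin-1-yl group on the thiocarbonyl carbon would fit the same trend.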